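Ethyl in Place of Fluoro: What to Expect for Compound 4

This account rests on a few compounds, and the source may have more. Where it says the series, first, only, none or still open, it means among the compounds named here.

Measured so far:
Compound 1 `CCc1cccc2cc(C(=O)O)cnc12`: in a functional assay on the whole organism (strain Sprague-Dawley) for inhibition, with Rattus norvegicus as the target (on this read-out lower numbers stand for an effect already at smaller amounts and higher numbers for an effect only at larger amounts of compound), compound 1 gives > 50 mg/kg, a limit of the assay rather than a number.
Compound 2 `O=c1c(-c2nn[nH]n2)c[nH]c2ccc(F)cc12`: in this assay compound 2 gives 1.25 mg/kg.
Compound 3 `O=C(O)c1cnc2c(F)cccc2c1`: in this assay compound 3 gives > 25 mg/kg, again a limit rather than a number.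

Compound 3 and compound 1 differ in one place, (ethyl in place of fluoro on an aromatic carbon). The step that the two limits leave unreadable from compound 3 to compound 1 cannot be read, since both ends sit at limits: the limit of > 25 mg/kg in this assay, at which 1 of the 3 values shown sits, and (the limit of > 50 mg/kg in this assay, at which 1 of the 3 values shown sits). Compound 4 `CCc1ccc2[nH]cc(-c3nn[nH]n3)c(=O)c2c1` is not yet measured; it differs from compound 2 by ethyl in place of fluoro on an aromatic carbon. This is the same kind of change as from compound 3 to compound 1, though the surroundings differ: there the place is ortho to a fused ring and meta to a fused ring, here meta to a fused ring and para to a fused ring. The difference between the two cores is not broken down here. Because a step that the two limits leave unreadable from compound 3 to compound 1 gives no readable size, the expectation rests on compound 2 alone with 1.25 mg/kg. Compound 4 is expected to move by a 1.2-fold higher number from compound 2 to compound 4 (0.08 log units; within the scatter). Compound 4 is therefore estimated at 1.5 mg/kg, between 0.5 mg/kg and 5 mg/kg.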

Compound 4, minimum effective dose: < 5 mg/kg
Compound 4: a limit, no number (the forecaster's own chance of this, stated with the estimate: 10%); the middle value is on the limit's open side.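

In this assay, among these compounds, compound 4 gives < 5 mg/kg, a limit rather than a number, so no step from compound 2 to compound 4 can be read. The compounds shown leave open how far ethyl in place of fluoro shifts the minimum effective dose in either pair.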